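Ring substituents on the chalcone series: carboxy at the open position

The compounds below may be only part of what the source reports. "The series", "measured", "known", "first", "only" and "open" are said of these compounds alone.

Measured so far:
compound 1, `O=C(/C=C/c1ccc2c(c1)B(O)OC2)c1ccccc1` — 15900 nM
compound 2, `COc1ccccc1C(=O)/C=C/c1ccc2c(c1)B(O)OC2` — 9100 nM
compound 3, `COCOc1cccc(C(=O)/C=C/c2ccc3c(c2)B(O)OC3)c1` — 48100 nM

In a toxicity assay on MCF-10A cells (Homo sapiens) for cytotoxicity, read by MTT assay, with a stated time of 48 h (a lower number here means a stronger inhibitor, a higher number a weaker inhibitor), compound 1 stands second highest of the three numbers; its nearest neighbour is compound 2, its furthest compound 3. The two measured steps from compound 1 both alter a hydrogen on an aromatic carbon of the benzoyl ring: a 1.7-fold lower number from compound 1 to compound 2 (0.24 log units; within the scatter), and a 3.0-fold higher number from compound 1 to compound 3 (0.48 log units; beyond the scatter). One substitution leaves the number where it was; the other raises it modestly.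

Compound 4, `O=C(O)c1ccc(C(=O)/C=C/c2ccc3c(c2)B(O)OC3)cc1`, is not yet measured in this assay. It differs from compound 1 by carboxy in place of hydrogen on an aromatic carbon, on an aromatic carbon para to a large group. The two steps measured on this ring are the only ones that bear on it. They range from no change to a modest rise, so a step of comparable size, toward a higher number, is the expectation, with a flat result not excluded given the step from compound 1 to compound 2.

For compound 4 the estimated value in this assay is 25000 nM, within 8000 nM to 80000 nM, corresponding to an expected 1.6-fold higher number from compound 1 to compound 4 (0.20 log units; within the scatter).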

Compound 4, half-maximal inhibitory concentration: > 100000 nM
Compound 4: no number, only a limit (the forecaster's own chance of this, stated with the estimate: 10%); middle value at least 4.0-fold (0.60 log units) away from the limit.
By their numbers in this assay, from the lowest: compounds 2 and 1 (each within the scatter of the next); then compound 3. At a limit, above all of these: compound 4.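

In this assay compound 4 reads > 100000 nM, which is a limit of the assay and not a number: the limit of > 100000 nM in this assay, at which 1 of the 4 values shown sits. Adding a carboxy group to the aromatic ring, para to a large group, gives an at least 6.2-fold higher number from compound 1 to compound 4 (0.79 log units; beyond the scatter), so this change on this ring can move the number well beyond the scatter, with the full size of the step left undefined by the limit. The earlier substitutions gave smaller readings, a 1.7-fold lower number from compound 1 to compound 2 (0.24 log units; within the scatter) and a 3.0-fold higher number from compound 1 to compound 3 (0.48 log units; beyond the scatter), and so the range of outcomes on this ring is wider than those two steps showed, and this change sits at its high end.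

The compounds shown do not separate the group from the position, since carboxy appears only para to a large group, while methoxy and methoxymethoxy stand elsewhere on the ring. A methyl ester or an amine at the same position, and a carboxylic acid at the places held by methoxy and methoxymethoxy, would be the comparisons that bear on this question.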